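This account rests on a few compounds, and the source may have more. Where it says the series, first, only, none or still open, it means among the compounds named here.

Measured compounds:
Compound 1, `Cc1nsc2[nH]cnc12`: 32000 nM
Compound 2, `CSc1nc2c(C)nsc2[nH]1`: 26000 nM
Compound 3, `Cc1nsc2c1ncn2[C@@H]1O[C@H](CO)[C@@H](O)[C@@H]1O`: a limit only, > 100000 nM

In a functional assay on HFF cells (Homo sapiens) for inhibition (on this read-out lower numbers stand for stronger inhibition and higher numbers for weaker inhibition), compound 1 gives 32000 nM and compound 2 gives 26000 nM. Compound 2 differs from compound 1 by methylsulfanyl in place of hydrogen on an aromatic carbon, and that step is a 1.2-fold lower number from compound 1 to compound 2 (0.09 log units; within the scatter). For compound 3 this assay reports only a limit, > 100000 nM, which is the limit described as the limit of > 100000 nM in this assay, at which 1 of the 3 values shown sits. The difference between the cores of compound 1 and compound 3 is not broken down here.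

Compound 4, `CSc1nc2c(C)nsc2n1[C@@H]1O[C@H](CO)[C@@H](O)[C@@H]1O`, differs from compound 3 by methylsulfanyl in place of hydrogen on an aromatic carbon. Around the place, compound 4 adds that it is next to the ring atom that bears a group of 9 heavy atoms, so this is the same kind of change. Because the same kind of change gave a 1.2-fold lower number from compound 1 to compound 2 (0.09 log units; within the scatter), the step from compound 3 to compound 4 in this assay is expected to be small, about a step that the limit leaves unreadable from compound 3 to compound 4. Compound 4 is therefore estimated at about 150000 nM, most likely again reported only as a limit.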

Compound 4, half-maximal inhibitory concentration: > 100000 nM
Compound 4: no number, only a limit (the forecaster's own chance of this, stated with the estimate: 75%); the middle value lies beyond the limit too.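

Compound 3 and compound 4 are both reported only as a limit, so the step between them cannot be read: the limit of > 100000 nM in this assay, at which 2 of the 4 values shown sit.

The compounds shown leave open how far beyond that limit each one lies, and whether methylsulfanyl in place of hydrogen changes anything there.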